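The source may hold more compounds than are shown below. What is called first, only, known or untested is meant among the compounds shown, and "the series" means these compounds.

Working notes on the coumarin-ether triazole series.

Among the measured compounds shown here, compound 1 `COc1ccc(-n2cc(COc3ccc4oc(=O)ccc4c3)nn2)cc1` is the only member with a number so far: in a functional assay on HL-60 cells (Homo sapiens) for cytotoxicity, read by MTT assay, with a stated time of 48 h (on this read-out higher numbers stand for weaker inhibition and lower numbers for stronger inhibition), compound 1 gives 46400 nM, a weak result on this read-out. Compound 2 `O=c1ccc2cc(OCc3cn(-c4cccc(CO)c4)nn3)ccc2o1` carries a hydroxymethyl on the phenyl of the triazole in place of the methoxy of compound 1; in this assay compound 2 is recorded as "not determined" (no result reported), so there is no single number on which compound 2 stands, and no comparison with compound 1 can be drawn for it.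

Compound 3 `O=c1ccc2cc(OCc3cn(-c4cccc([N+](=O)[O-])c4)nn3)ccc2o1` differs from compound 2 in one place: nitro in place of hydroxymethyl on an aromatic carbon. For the measured compounds named here, with no measured step available, the size and direction of the change from compound 2 to compound 3 in this assay cannot be read off; the only anchor is the weak value of compound 1, and a result of the same order, within the usual scatter of that anchor, is expected rather than a marked shift in either direction.

On that basis compound 3 is estimated in this assay at 30000 nM, with an expected range from 8000 nM to 100000 nM.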

Compound 3, half-maximal inhibitory concentration: 20500 nM
Beside the measured number, compound 3's estimate is 1.5-fold (0.17 log units) above it; measured number inside the range.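

The series now has its first readable step: in this assay, 3-nitrophenyl in place of 4-methoxyphenyl on an aromatic nitrogen gives a 2.3-fold lower number from compound 1 to compound 3 (0.35 log units; beyond the scatter). This shows that the aryl group at this position can move the read-out beyond the usual scatter, although only modestly, and that the nitro group is compatible with activity in this assay. The step changes both the substituent and where it sits on the phenyl ring, so the contribution of each cannot be separated, the step from compound 2 to compound 3 cannot be read because compound 2 has no number, and nothing at hand gives a reason for the shift.

From the compounds shown here alone, it remains open whether an amine, a carboxylic acid or a longer chain such as ethoxyethyl on the same phenyl ring would carry the read-out further in either direction or leave it within the scatter. Also open, going by these compounds, is whether the hydroxymethyl of compound 2 would stand closer to the nitro of compound 3 or to the methoxy of compound 1, so the direction of the hydroxymethyl-to-nitro change remains unknown.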